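Ring nitrogen substituent and permeability of compound 4

This account rests on a few compounds, and the source may have more. Where it says the series, first, only, none or still open, it means among the compounds named here.

Compound 1 `CCCC[C@H](NC(=O)[C@H](CCCCN)NC(=O)[C@H](CCCNC(=N)N)NC(=O)c1ccc(/C=C2\SC(=O)N(c3ccc(C)cc3)C2=O)cc1)C(N)=O`: 0.66 10^-6 cm/s
Compound 2 `CCCC[C@H](NC(=O)[C@H](CCCCN)NC(=O)[C@H](CCCNC(=N)N)NC(=O)c1ccc(/C=C2\SC(=S)N(CCCC)C2=O)cc1)C(N)=O`: 1.61 10^-6 cm/s
Compound 3 `CCCC[C@H](NC(=O)[C@H](CCCCN)NC(=O)[C@H](CCCNC(=N)N)NC(=O)c1ccc(/C=C2\SC(=S)N(Cc3ccc(OC)cc3)C2=O)cc1)C(N)=O`: 0.6 10^-6 cm/s

The three measured compounds share one core and differ only in the group carried on the amide-type nitrogen of the five-membered ring. In an ADME assay for permeability, using PAMPA (on this read-out higher numbers stand for higher permeability and lower numbers for lower permeability), compound 1 stands second highest of the three numbers. Its nearest neighbour is compound 3, whose value lies within the scatter of that of compound 1, while compound 2 lies beyond the scatter above it. Among the measured compounds shown here, the only measured step at this position is a 2.7-fold lower number from compound 2 to compound 3 (0.43 log units; beyond the scatter), in which a chain gave way to a group containing an aromatic ring.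

Compound 4 `CCCC[C@H](NC(=O)[C@H](CCCCN)NC(=O)[C@H](CCCNC(=N)N)NC(=O)c1ccc(/C=C2\SC(=O)N(Cc3ccc(Cl)cc3)C2=O)cc1)C(N)=O` has not yet been measured. It differs from compound 1 by 4-chlorobenzyl in place of 4-methylphenyl on an amide-type nitrogen in a ring. Here one aromatic group replaces another, so the step from compound 2 to compound 3 is only a loose guide; compound 1 and compound 3, which both carry an aromatic group at this nitrogen, sit within the scatter of each other. Compound 4 is therefore expected to stay close to compound 1, with a 1.0-fold lower number from compound 1 to compound 4 (0.01 log units; within the scatter) not beyond the scatter. The estimate for compound 4 in this assay is 0.65 10^-6 cm/s, between 0.3 10^-6 cm/s and 1.3 10^-6 cm/s.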

Compound 4, apparent permeability: 1.11 10^-6 cm/s
Estimate against measurement, compound 4: 1.7-fold (0.23 log units) below; the measured number falls inside the stated range.
By their numbers in this assay, from the lowest: compounds 3, 1, 4 and 2 (each within the scatter of the next, the first and the last beyond it).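

In this assay, among the compounds shown here, putting 4-chlorobenzyl in place of 4-methylphenyl on the amide-type nitrogen in a ring gave a 1.7-fold higher number from compound 1 to compound 4 (0.23 log units; within the scatter), the first step at this position between two groups that each hold a six-membered aromatic ring of carbon only. Unlike a 2.7-fold lower number from compound 2 to compound 3 (0.43 log units; beyond the scatter), where a chain gave way to an aromatic group, this exchange stays within the scatter, although compounds 2 and 3 also carry a thiocarbonyl where compounds 1 and 4 carry a carbonyl, so the two steps come from different backgrounds. Nothing available here bears on why the number of compound 4 fell where it did.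

This single step changes the carbon link to the nitrogen and the substituent on the aromatic ring together, so it cannot separate the share of each, and a plain benzyl or a 4-chlorophenyl group would be needed to tell them apart. Also open, going by these compounds, is how a butyl chain, as in compound 2, would read on the carbonyl background of compound 1, and how this assay would respond to an amine or a carboxylic acid in the group on this nitrogen.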